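The source may hold more compounds than are shown below. What is called first, only, known or untested is meant among the compounds shown, and "the series" means these compounds.

Measured so far in a functional assay on MCF7 cells (Homo sapiens) for antiproliferative activity, read by MTT assay, with a stated time of 48 h; a higher number here means a weaker inhibitor, a lower number a stronger inhibitor:
compound 1 (`Cc1nc(-c2ccccc2)sc1C(=O)CSc1nc(N)c(C#N)c(-c2ccccc2)n1`) gives 30100 nM
compound 2 (`Cc1nc(-c2ccc(Cl)cc2)sc1C(=O)CSc1nc(N)c(C#N)c(-c2ccc(Cl)cc2)n1`) gives 12500 nM

Compound 2 holds the lower number of the two, and its gap to compound 1 lies beyond the scatter. Next comes compound 3 (`Cc1nc(-c2ccc(Cl)cc2)sc1C(=O)CSc1nc(N)c(C#N)c(-c2ccccc2)n1`), which differs from compound 2 by hydrogen in place of chloro on an aromatic carbon. One 4-chlorophenyl thus becomes phenyl, while the other stays. For the measured compounds named here, no single-place step has been measured, so the expectation rests on two values: compound 1, with phenyl in both places, gives 30100 nM, and compound 2 gives 12500 nM. Compound 3 carries one of these two differences. The expected 1.5-fold higher number from compound 2 to compound 3 (0.18 log units; within the scatter) is small, toward a higher number, and may stay within the scatter. For compound 3 the estimated value is 19000 nM, with an expected range from 10000 nM to 36000 nM.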

Compound 3, half-maximal inhibitory concentration: 25200 nM
Estimate against measurement, compound 3: 1.3-fold (0.12 log units) below; low and high end bracket the measured number.
By their numbers in this assay, from the lowest: compounds 2, 3 and 1 (each within the scatter of the next, the first and the last beyond it).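

In this assay, the exchange of 4-chlorophenyl to phenyl can now be read one place at a time: the place on the aromatic ring that changes between compound 2 and compound 3 gives a step that stays within the scatter (a 2.0-fold higher number from compound 2 to compound 3 (0.30 log units; within the scatter)), and chloro in place of hydrogen on the other phenyl, taken alone, also stays within it (a 1.2-fold lower number from compound 1 to compound 3 (0.08 log units; within the scatter)). At neither place, then, does a single chloro give a step beyond the scatter. No measurement at hand accounts for either step.

Still open, going by these compounds, is whether a different group at the same place, such as methoxy, an amine or a carboxylic acid, would give a step beyond the scatter. A larger group such as a second fused benzene ring also remains untested in the compounds shown here.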